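The source may hold more compounds than are shown below. What is called first, only, known or untested is meant among the compounds shown, and "the series" means these compounds.

Measured so far:
compound 1, `C#CCNC1CCc2c(SCCc3cccc(C)c3)cccc21` — 4960 nM
compound 2, `C#CCNC1CCc2c(SCc3ccc(Br)cc3)cccc21` — 488 nM

Both compounds were run in an ADME assay on isolated protein for inhibition of Amine oxidase [flavin-containing] B (Homo sapiens); a higher number here means a weaker inhibitor, a lower number a stronger inhibitor. Of the two numbers, compound 1 stands highest; compound 2 is the nearer one, and its number lies well beyond the scatter below that of compound 1. No stepwise comparison between these two is drawn here, as they differ in more than one place; only the two values themselves are set side by side.

The next compound on the same core is compound 3, `C#CCNC1CCc2c(SCCc3cccc(F)c3)cccc21`, not yet measured in this assay. Its difference from compound 1 is a single exchange on the aromatic ring at the end of the chain: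

fluoro in place of methyl on an aromatic carbon

Fluoro thus takes the place of methyl on an aromatic carbon, with no change in ring count, donors, acceptors or charge. Within the data shown here, nothing among the measured compounds shows what such an exchange does here, so the expected step in this assay is small, in either direction, and most likely within the scatter; if anything, a slightly lower number is expected. Compound 3 is accordingly estimated at 3800 nM, with a range from 1400 nM to 10000 nM, which corresponds to an expected step of a 1.3-fold lower number from compound 1 to compound 3 (0.12 log units; within the scatter).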

Compound 3, half-maximal inhibitory concentration: 7810 nM
The estimate for compound 3 lay 2.1-fold (0.31 log units) below the measured number; the range from low to high includes it.
By their numbers in this assay, from the lowest: compound 2; then compounds 1 and 3 (each within the scatter of the next).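

In this assay, among these compounds, the exchange of 3-methylphenyl for 3-fluorophenyl gives the first step that can be read (a 1.6-fold higher number from compound 1 to compound 3 (0.20 log units; within the scatter)). For this one pair, methyl and fluoro on an aromatic carbon, meta to a large group, are therefore not told apart by this read-out, and the exchange leaves the compound in the same range within the scatter. Nothing measured on these compounds bears on this result, so it rests on the two numbers alone.

Among the compounds shown here, the pair leaves open whether a group of a different kind at this place, such as methoxy, trifluoromethyl, an amine or a carboxylic acid, would give a step beyond the scatter, since methyl and fluoro are the only groups seen here. Compound 2 differs from compound 1 and from compound 3 in more than one place, so the contributions of the chain and of the ring substituent remain unseparated, and a compound with the shorter chain and the 3-fluorophenyl group would be needed to read them one at a time.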